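Adding a second methoxy to compound 2: a cytotoxicity estimate

The source may hold more compounds than are shown below. What is called first, only, known or untested is meant among the compounds shown, and "the series" means these compounds.

Of the compounds shown here, three sharing a pyrazine ester core have been tested in a functional assay on EA.hy 926 cells (Homo sapiens) for cytotoxicity, read by MTT assay, with stated times of 24 h and 12 h, tested at 50 uM; on this read-out higher numbers stand for a stronger effect at the one concentration tested and lower numbers for a weaker effect. Compound 2 `COc1cc(/C=C/C(=O)O)ccc1OC(=O)c1nc(C)c(C)nc1C` gives 49.1%, the highest of the three numbers; compound 1 `COc1ccc(/C=C/C(=O)O)c(OC(=O)c2nc(C)c(C)nc2C)c1` gives 31.6%, and compound 3 `CCOC(=O)/C=C/c1ccc(OC)cc1OC(=O)c1nc(C)c(C)nc1C` gives 20.7%. Within the data shown here, the one single-point step among them, ethyl in place of hydrogen on an oxygen next to a carbonyl group, moved the read-out by a number 10.9 percentage points lower from compound 1 to compound 3 (beyond the scatter).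

Compound 4 `COc1cc(/C=C/C(=O)O)cc(OC)c1OC(=O)c1nc(C)c(C)nc1C` is still to be measured. It differs from compound 2 by methoxy in place of hydrogen on an aromatic carbon, a methoxy in place of hydrogen on an aromatic carbon. Among the measured compounds shown here, no measured step in this set concerns a methoxy entering the aromatic ring; the only measured step touches the acid group and says nothing about this change. Compound 1 and compound 2 differ in where their groups sit, not by one added group, so their two values show only that arrangement matters here.

For the measured compounds named here, with no step that bears on it, compound 4 is expected to remain near compound 2, the estimated step being a number 4.1 percentage points lower from compound 2 to compound 4 (within the scatter), within the scatter. In this assay compound 4 is thus estimated at 45%, plausibly between 30% and 60%.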

Compound 4, a percentage reported as activity, at one concentration (the size of the read-out at that concentration, not a potency): 96.6%
Compound 4: the middle estimate sits 51.6 percentage points below what was measured, outside the stated range (above it).
By their numbers in this assay, from the lowest: compound 3; then compound 1; then compound 2; then compound 4.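

In this assay, methoxy in place of hydrogen on an aromatic carbon, ortho to a large group and meta to a 2-carboxyethenyl group, moves the read-out by a number 47.5 percentage points higher from compound 2 to compound 4 (beyond the scatter). Among these compounds, this position is therefore one where a single added methoxy counts heavily, something the earlier compounds could not show, as they differ only at the acid group or in the arrangement of their groups. Nothing measured in this set accounts for the size of this step.

As far as these compounds go, it remains open whether another group on this aromatic carbon, such as a hydroxyl, an ethoxy or an amine, would give a similar read-out. From the compounds shown here alone, it is also open whether the added methoxy would give a like step with an ethyl ester in place of the carboxylic acid.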